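From 4-methoxyphenyl to 2-ethoxyphenyl on a shared core

The source may report more compounds than this note shows. Statements on the series, on what has been measured and on what is new or still open speak of the compounds shown alone.

Three measured compounds share one core and differ only in the aromatic ring on the amine nitrogen. In a functional assay on ECa-109 cells for inhibition, with ECa-109 cell line (Homo sapiens) as the target, read by sulforhodamine B assay (a higher number here means a weaker inhibitor, a lower number a stronger inhibitor), compound 1 `O=C1C(Nc2ccc(I)cc2)=CC(=O)c2c1nc1n2[C@H]2OC[C@@H](O)[C@H]2OC1` gives 2530 nM, compound 2 `O=C1C(Nc2ccccc2)=CC(=O)c2c1nc1n2[C@H]2OC[C@@H](O)[C@H]2OC1` gives 3560 nM, and compound 3 `COc1ccc(NC2=CC(=O)c3c(nc4n3[C@H]3OC[C@@H](O)[C@H]3OC4)C2=O)cc1` gives 3410 nM. Compound 3 cannot be told apart from the other two, as the data show a 1.0-fold lower number from compound 2 to compound 3 (0.02 log units; within the scatter) and a 1.3-fold higher number from compound 1 to compound 3 (0.13 log units; within the scatter). The remaining comparison is a 1.4-fold higher number from compound 1 to compound 2 (0.15 log units; within the scatter). Exchanging hydrogen, iodo and methoxy on this ring has therefore produced no measurable difference among these compounds.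

Compound 4 `CCOc1ccccc1NC1=CC(=O)c2c(nc3n2[C@H]2OC[C@@H](O)[C@H]2OC3)C1=O` brings a different kind of change: 2-ethoxyphenyl in place of 4-methoxyphenyl on an amine nitrogen. None of the three measured compounds carries a 2-ethoxyphenyl group, so their steps offer only indirect guidance. Taking compound 3 at 3410 nM as the starting point, with a 1.0-fold lower number from compound 2 to compound 3 (0.02 log units; within the scatter) as the closest precedent, no shift beyond the scatter is expected in this assay. The estimated step is a 1.0-fold lower number from compound 3 to compound 4 (0.00 log units; within the scatter). The untested group leaves real uncertainty, so the expected range is kept wide. For compound 4 the estimated value is 3400 nM, with an expected range from 1500 nM to 7500 nM.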

Compound 4, half-maximal inhibitory concentration: 4320 nM
Beside the measured number, compound 4's estimate is 1.3-fold (0.10 log units) below it, and the stated range covers the measured number.
By their numbers in this assay, from the lowest: compounds 1, 3, 2 and 4 (each within the scatter of the next).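

In this assay, the 2-ethoxyphenyl group differs from the 4-methoxyphenyl group in both the chain on oxygen and the place of that oxygen-bearing group on the ring, yet the result is a 1.3-fold higher number from compound 3 to compound 4 (0.10 log units; within the scatter) and stays inside the usual variation. Within the data shown here, the comparison with the plain phenyl compound gives a 1.2-fold higher number from compound 2 to compound 4 (0.08 log units; within the scatter), and the one with the 4-iodophenyl compound gives a 1.7-fold higher number from compound 1 to compound 4 (0.23 log units; within the scatter), which is the largest of these new steps but is still not a measurable difference. So this position on the amine nitrogen has now accepted a new substituent and a new ring position with no change that these data can resolve, and nothing available explains why the four values stay so close.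

The step from compound 3 to compound 4 joins two changes in one, and only 2-methoxyphenyl and 4-ethoxyphenyl groups could separate them. From the compounds shown here alone, it also remains open whether a very different group on this nitrogen, such as a carboxylic acid on the ring or a saturated chain ending in an amine in place of the ring, would move the number beyond the usual variation.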